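Swapping phenyl for piperidinylmethyl on a shared core

This account rests on a few compounds, and the source may have more. Where it says the series, first, only, none or still open, it means among the compounds named here.

Of the compounds shown here, three built on one core have been tested in a functional assay on the whole organism (B cells) with Mus musculus as the target; a lower number here means a smaller maximal response, a higher number a larger maximal response. Compound 1 `Nc1nc(O)c2c(n1)n(C1OC(CO)[C@@H](O)[C@H]1O)c(=O)n2CC(O)CSc1ccccc1` gives 12%. Compound 2 `NC(=O)Cn1c(=O)n(C2OC(CO)[C@@H](O)[C@H]2O)c2nc(N)nc(O)c21` gives 32%. Compound 3 `Nc1nc(O)c2c(n1)n(C1OC(CO)[C@@H](O)[C@H]1O)c(=O)n2Cc1ccccc1` gives 110%, the highest of the three numbers; the steps of a number 78 percentage points higher from compound 2 to compound 3 (beyond the scatter) and a number 98 percentage points higher from compound 1 to compound 3 (beyond the scatter) are both beyond the scatter, so compound 3 stands clearly above the other two in this assay. The smaller step of a number 20 percentage points higher from compound 1 to compound 2 (beyond the scatter) separates the two lower compounds.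

Compound 4 `Nc1nc(O)c2c(n1)n(C1OC(CO)[C@@H](O)[C@H]1O)c(=O)n2CCN1CCCCC1` differs from compound 3 by one change: (piperidin-1-yl)methyl in place of phenyl on a saturated chain carbon bound to an aromatic nitrogen. Among the measured compounds shown here, no measured step exchanges phenyl for a six-membered non-aromatic ring with 1 hetero atom, so the nearest guides are the steps that brought the phenyl in. The step of a number 78 percentage points higher from compound 2 to compound 3 (beyond the scatter) and the step of a number 98 percentage points higher from compound 1 to compound 3 (beyond the scatter) show that the two other groups tried on this saturated chain carbon gave far lower responses, and neither was a ring. From the compounds shown here alone, a drop is therefore expected, though how much of the response a saturated ring retains is unknown. In this assay the expected change is a number 70 percentage points lower from compound 3 to compound 4 (beyond the scatter). In this assay compound 4 is estimated at 40%, within a range from 10% to 90%.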

Compound 4, largest response reached (reported as maximal response), in percent of the reference or control that the assay uses: 0%
For compound 4 the middle estimate is 40 percentage points above the measured one; measured number outside the range, below it.
By their numbers in this assay, from the lowest: compound 4; then compound 1; then compound 2; then compound 3.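

In this assay, putting (piperidin-1-yl)methyl in place of phenyl on a saturated chain carbon bound to an aromatic nitrogen removes the whole response (a number 110 percentage points lower from compound 3 to compound 4 (beyond the scatter)), so a six-membered ring at this place is not enough to keep the response of compound 3. Compound 4 also falls under both low compounds (a number 32 percentage points lower from compound 2 to compound 4 (beyond the scatter); a number 12 percentage points lower from compound 1 to compound 4 (beyond the scatter)), which makes it the lowest of the four, and among the groups shown only the phenyl of compound 3 gives a high response, although compound 1 also carries a phenyl, within its 1-hydroxy-2-(phenylsulfanyl)ethyl group. Nothing presented here accounts for this loss of response.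

The step from benzyl to 2-(piperidin-1-yl)ethyl changes the aromatic ring to a non-aromatic one, adds a nitrogen and lengthens the chain all at once, so the compounds shown cannot say which of these changes matters. A 2-phenylethyl group would test the longer chain with the phenyl kept, and a cyclohexylmethyl group would test a non-aromatic ring of carbon only at the same place.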